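Notes on the step from compound 2 to compound 4

A few compounds are considered here, and "the series" means these few. Any claim that something is new, unique, unknown or untested is made for them only; others in the source may bear on it.

Values in an assay on isolated protein for binding affinity to Leucine-rich repeat serine/threonine-protein kinase 2 variant G2019S (Homo sapiens), read by TR-FRET and LanthaScreen, with a stated time of 2 h; on this read-out higher numbers stand for weaker inhibition and lower numbers for stronger inhibition:
compound 1, `C[C@@H]1CCCN1c1c(C#N)c2c(N)nc(Nc3ccn(C)n3)cc2n1C`: 13 nM
compound 2, `CN(C)c1c(C#N)c2c(N)ncnc2n1C`: 259 nM
compound 3, `Cc1n[nH]cc1Nc1nc(N)c2c(C#N)c(N3CCC[C@H]3C)n(C)c2n1`: 2 nM

Compound 2 stands highest of the three numbers in this assay; compound 1 and compound 3 both lie lower, each beyond the scatter, and both carry further changes on the shared core, so neither gives a one-step comparison to compound 2.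

Compound 4, `Cn1c(-c2ccccc2)c(C#N)c2c(N)ncnc21`, differs from compound 2 in one place: phenyl in place of dimethylamino on an aromatic carbon. Among the measured compounds shown here, no step between measured compounds covers this change, and the dimethylamino group of compound 2 has no counterpart elsewhere in the set. The step of a 1.2-fold higher number from compound 2 to compound 4 (0.06 log units; within the scatter) is therefore expected to stay within the scatter, with no direction claimed. Compound 4 is estimated at 300 nM in this assay, in the range 60 nM to 1500 nM.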

Compound 4, inhibition constant: 33 nM
For compound 4 the middle estimate is 9.1-fold (0.96 log units) above the measured one; the whole stated range lies above it.
By their numbers in this assay, from the lowest: compound 3; then compound 1; then compound 4; then compound 2.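

In this assay, phenyl in place of dimethylamino on this aromatic carbon gives a 7.8-fold lower number from compound 2 to compound 4 (0.89 log units; beyond the scatter) and shows that the number at this position responds to the group it carries. A six-membered aromatic ring of carbon only is accepted here, with no hydrogen-bond acceptor in the entering group. No available evidence bears on the origin of this step.

As far as these compounds go, whether the ring itself matters, or only the loss of dimethylamino, stays open. A cyclohexyl or pyridyl ring, or a single methyl group, on this carbon would help to separate the two.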